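The source may report more compounds than this note shows. Statements on the series, on what has been measured and on what is new or still open speak of the compounds shown alone.

Measured so far in an ADME assay for permeability, using PAMPA, with a stated time of 4 h, at pH 5.5; a lower number here means that the compound crosses the layer more slowly, a higher number that the compound crosses the layer faster:
- compound 1 `NC(=O)NC/C=C\CN(C[C@H]1Cc2ncccc2CN1)[C@H]1CCCc2cccnc21`: 5 nm/s
- compound 2 `NC(=O)NC/C=C/CN(C[C@H]1Cc2ncccc2CN1)[C@H]1CCCc2cccnc21`: 6 nm/s
- compound 3 `c1cnc2c(c1)CN[C@@H](CN(CCCCNC1CCOCC1)[C@H]1CCCc3cccnc31)C2`: 2 nm/s

Compound 1 and compound 2 sit within the scatter of each other, with a 1.2-fold higher number from compound 1 to compound 2 (0.08 log units; within the scatter); this pair reflects (the fact that compounds 1 and 2 differ only in the configuration as drawn). Compound 3, at 2 nm/s, stands lowest of the three, and both of its gaps lie beyond the scatter.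

The next compound is compound 4 `c1cnc2c(c1)CN[C@@H](CN(CCCCNC1COC1)[C@H]1CCCc3cccnc31)C2`, which keeps the shared core and the chain of compound 3. Its change is oxetan-3-yl in place of oxan-4-yl on an amine nitrogen. In short, oxetan-3-yl takes the place of oxan-4-yl on an amine nitrogen, so one non-aromatic ring replaces another.

Among the compounds with values here, no measured step makes this exact swap. The closest evidence comes from two steps that replaced an open group with a group holding a ring, giving a 2.5-fold lower number from compound 1 to compound 3 (0.40 log units; beyond the scatter) and a 3.0-fold lower number from compound 2 to compound 3 (0.48 log units; beyond the scatter). Both are modest, and the swap in compound 4 exchanges a ring for a ring rather than adding one. On that basis, no step beyond the scatter is expected in this assay.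

The expected change is a 1.5-fold higher number from compound 3 to compound 4 (0.18 log units; within the scatter).

For compound 4 the estimated value is 3 nm/s, with an expected range of 1 nm/s to 6 nm/s.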

Compound 4, apparent permeability: 7 nm/s
Compound 4: middle estimate off by 2.3-fold (0.37 log units), on the low side, and the stated range ends below it.
By their numbers in this assay, from the lowest: compound 3; then compounds 1, 2 and 4 (each within the scatter of the next).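

In this assay, within the data shown here, this is the first step that changes only the ring on the amine nitrogen, keeping the shared core and the chain, and it is large enough to read: a 3.5-fold higher number from compound 3 to compound 4 (0.54 log units; beyond the scatter). It also shows that carrying a ring at this end of the molecule does not by itself put a compound at the low end, since the steps from the two compounds with the open group, a 1.2-fold higher number from compound 2 to compound 4 (0.07 log units; within the scatter) and a 1.4-fold higher number from compound 1 to compound 4 (0.15 log units; within the scatter), both stay within the scatter, unlike their steps to compound 3. Nothing measured here accounts for the difference between oxetan-3-yl and oxan-4-yl in this assay.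

The compounds shown carry only these two rings on this amine nitrogen, so it remains open where a ring of intermediate size, such as oxolan-3-yl, would fall, or whether a ring holding nitrogen instead of oxygen, such as azetidin-3-yl, would behave like oxetan-3-yl. On these data alone, it also remains open whether the same swap gives a similar step on a shorter chain.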